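The source may hold more compounds than are shown below. What is called first, only, known or untested is meant among the compounds shown, and "the series" means these compounds.

Measured so far:
compound 1, `Nc1nc(N/N=C/c2ccc3ncccc3c2)nc2c1ncn2[C@@H]1O[C@H](CO)[C@@H](O)[C@H]1O`, 9.8 nM
compound 2, `CCOc1cc(/C=N/Nc2nc(N)c3ncn([C@@H]4O[C@H](CO)[C@@H](O)[C@H]4O)c3n2)ccc1O`, 6940 nM
compound 3, `Nc1nc(N/N=C/c2cccnc2Cl)nc2c1ncn2[C@@H]1O[C@H](CO)[C@@H](O)[C@H]1O`, 4.6 nM

All three numbers come from an assay on CHO-K1 cells for displacement of a labelled ligand from adenosine receptor A1 (Homo sapiens), read by scintillation counting, with a stated time of 60 min; on this read-out higher numbers stand for weaker inhibition and lower numbers for stronger inhibition. Compound 3 gives the lowest of them; compound 1 lies nearest, a 2.1-fold lower number from compound 1 to compound 3 (0.33 log units; beyond the scatter), and compound 2 lies furthest, a 1500-fold lower number from compound 2 to compound 3 (3.18 log units; beyond the scatter). Compound 4, `N#Cc1ccccc1/C=N/Nc1nc(N)c2ncn([C@@H]3O[C@H](CO)[C@@H](O)[C@H]3O)c2n1`, differs from compound 3 by 2-cyanophenyl in place of 2-chloropyridin-3-yl on a carbon with a double bond to nitrogen. The steps at this position are the two large ones, a 710-fold higher number from compound 1 to compound 2 (2.85 log units; beyond the scatter) and the step to compound 3 already quoted, plus the modest step from compound 1. Compound 1 and compound 3, whose rings carry no hydrogen-bond donor, both gave low numbers, and 2-cyanophenyl likewise carries none, so only a small upward step in this assay is expected. Compound 4 is estimated at 8 nM, range 2 nM to 40 nM, meaning an expected 1.7-fold higher number from compound 3 to compound 4 (0.24 log units; within the scatter).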

Compound 4, inhibition constant: 2.9 nM
Estimate against measurement, compound 4: 2.8-fold (0.44 log units) above; the measured number falls inside the stated range.
By their numbers in this assay, from the lowest: compounds 4 and 3 (each within the scatter of the next); then compound 1; then compound 2.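

In this assay, 2-cyanophenyl in place of 2-chloropyridin-3-yl leaves the number within the scatter (a 1.6-fold lower number from compound 3 to compound 4 (0.20 log units; within the scatter)), so a ring of carbon only can sit on this carbon with a low number, and it also compares well with quinolin-6-yl (a 3.4-fold lower number from compound 1 to compound 4 (0.53 log units; beyond the scatter)). Compound 2 also has a ring of carbon only, yet 3-ethoxy-4-hydroxyphenyl stands far from 2-cyanophenyl (a 2400-fold lower number from compound 2 to compound 4 (3.38 log units; beyond the scatter)), so the absence of a ring nitrogen does not by itself set the number. Nothing available explains these steps.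

On these data alone, whether an amine or a carboxylic acid on the phenyl ring keeps the number low remains open. So does whether the ethoxy or the hydroxy group of compound 2 goes with its high number.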